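The compounds below may be only part of what the source reports. "The series", "measured", "known", "first", "only" and "open" are said of these compounds alone.

Measured so far in an assay on isolated protein for inhibition of Amine oxidase [flavin-containing] A (Homo sapiens), read by fluorescence and Amplex Red, with a stated time of 15 min, tested at 50 uM; a lower number here means less inhibition, a higher number more inhibition at the concentration tested (going by the name of the read-out):

compound 1 `C#CCN(CC)Cc1cn(-c2cc(NC(=S)NCC)ncn2)cn1` — compound 1 gives 6.71%
compound 2 `C#CCN(Cc1cn(-c2cc(NC(=S)NCC)ncn2)cn1)C(C)=O` — compound 2 gives 4.83%
compound 3 `C#CCN(CC#N)Cc1cn(-c2cc(NC(=S)NCC)ncn2)cn1` — compound 3 gives 2.01%

Compound 3 sits at the smallest of the three numbers, but all three lie within the usual scatter of one another: the nearest number is that of compound 2, the furthest that of compound 1, and neither gap counts as a real difference. Within the data shown here, every step so far changes only the substituent on the amine nitrogen of the side chain: a number 1.9 percentage points lower from compound 1 to compound 2 (within the scatter), a number 4.7 percentage points lower from compound 1 to compound 3 (within the scatter) and a number 2.8 percentage points lower from compound 2 to compound 3 (within the scatter). None of these reaches beyond the scatter, so three variations at this position have left this assay flat.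

Compound 4 `C#CCN1CCN(Cc2cn(-c3cc(NC(=S)NCC)ncn3)cn2)CC1` carries the next change at the same region: a group of 9 heavy atoms (7 carbon, 2 nitrogen; one six-membered non-aromatic ring with 2 hetero atoms) in place of a group of 7 heavy atoms (5 carbon, 2 nitrogen; no ring), on a saturated chain carbon bound to an aromatic carbon. Among the measured compounds shown here, it is a larger alteration than the three measured ones, since the open chain is closed into a ring, but the three measured steps are the only guide, and all were within the scatter. The expected outcome is therefore a number 3 percentage points higher from compound 3 to compound 4 (within the scatter), that is, no step beyond the scatter. Compound 4 is thus estimated at 5%, with a range from 0% to 15%.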

Compound 4, a percentage reported as inhibition, at one concentration (the size of the read-out at that concentration, not a potency): 9.22%
For compound 4 the middle estimate is 4.2 percentage points below the measured one; the range from low to high includes it.
By their numbers in this assay, from the lowest: compounds 3, 2, 1 and 4 (each within the scatter of the next).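

Closing the open chain into the 4-propargylpiperazin-1-yl group still leaves this assay flat: a number 7.2 percentage points higher from compound 3 to compound 4 (within the scatter) stands with a number 4.4 percentage points higher from compound 2 to compound 4 (within the scatter) and a number 2.5 percentage points higher from compound 1 to compound 4 (within the scatter) as steps that do not reach beyond the scatter. The flat picture at this position therefore extends from open-chain substituents on the amine nitrogen to a six-membered non-aromatic ring with 2 hetero atoms, and all four compounds lie within the scatter of one another, so the ring gives no separation from the open-chain compounds at the single concentration tested. Nothing available here explains why closing the ring leaves the read-out in the same band.

Open, from the compounds shown here alone, is whether a morpholine ring in place of the piperazine, or a carboxylic acid or a longer chain on the amine nitrogen, would give a step beyond the scatter at this position. Also open, going by these compounds, is whether any change on the shared core, away from this side chain, would move the number where these four side chains have not.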